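A few compounds are considered here, and "the series" means these few. Any claim that something is new, unique, unknown or untested is made for them only; others in the source may bear on it.

Compound 2 `CCC(C)(C)Cc1c[nH]c(CCc2ccc(-c3cnsc3)cc2)n1` gives 10 nM in an in vitro assay on CHO cells for displacement of a labelled ligand from Bombesin receptor subtype-3 (Homo sapiens), read by scintillation counting, with a stated time of 2 h; a higher number here means a weaker inhibitor, a lower number a stronger inhibitor; compound 1 `CCC(C)(C)Cc1c[nH]c(CCc2ccc(-c3ccccc3C(=O)O)cc2)n1` gives 11 nM, and the two numbers sit within the scatter of each other, so neither stands apart. Compound 3 `CCC(C)(C)Cc1c[nH]c(CCc2ccc(-c3ccns3)cc2)n1` differs from compound 2 in one place: 1,2-thiazol-5-yl in place of 1,2-thiazol-4-yl on an aromatic carbon. Within the data shown here, the only measured step at this position, a 1.1-fold lower number from compound 1 to compound 2 (0.04 log units; within the scatter), shows that a far larger swap there left the number unchanged. Compound 3 is therefore expected to show a step of a 1.5-fold higher number from compound 2 to compound 3 (0.18 log units; within the scatter), nothing beyond the scatter. The estimate for compound 3 is 15 nM, with a range of 5 nM to 45 nM.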

Compound 3, half-maximal inhibitory concentration: 11 nM
Estimate against measurement, compound 3: 1.4-fold (0.13 log units) above, and the stated range covers the measured number.
By their numbers in this assay, from the lowest: compounds 2, 1 and 3 (each within the scatter of the next).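

The two isomers, with the same atoms joined differently, show a 1.1-fold higher number from compound 2 to compound 3 (0.04 log units; within the scatter) so the change from 1,2-thiazol-4-yl to 1,2-thiazol-5-yl on this aromatic carbon does not move the number beyond the scatter. Against the 2-carboxyphenyl compound, the step is no change at the digits printed from compound 1 to compound 3 (within the scatter) and a second five-membered aromatic ring now matches that group as well. Nothing available explains this flat response. Still open, on these data alone, is whether an amine, a longer chain or a plain hydrogen at this position would keep the number in the same range.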